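This account rests on a few compounds, and the source may have more. Where it says the series, first, only, none or still open, it means among the compounds named here.

Measured so far:

compound 1 `O=C1NC(O)(/C=C\n2cc(I)c3c(Cl)ncnc32)C(OCc2ccccc2)=C1OCc1ccccc1` — 22600 nM
compound 2 `O=C1O/C(=C\Cn2cnc3c(F)nc(F)c(Cl)c32)C(OCc2ccccc2)=C1OCc1ccccc1` — 78000 nM
compound 3 `O=C1NC(O)(CCn2cnc3cncc(Br)c32)C(OCc2ccccc2)=C1OCc1ccccc1` — 48700 nM

All three compounds were tested in a functional assay on MIA PaCa-2 cells (Homo sapiens) for antiproliferative activity, read by MTT assay, with a stated time of 72 h; a higher number here means a weaker inhibitor, a lower number a stronger inhibitor. Compound 2 gives the highest number of the three; compound 3 sits closest to it, within the scatter, while compound 1 lies furthest away, beyond the scatter. Among the measured compounds shown here, no single-point step between these measured compounds can be drawn, so the values simply stand side by side, and all three point to weak inhibition of cell growth.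

Compound 4 `O=C1O/C(=C\Cn2cnc3cc[nH]c3c2=O)C(OCc2ccccc2)=C1OCc1ccccc1` has not yet been measured. It differs from compound 2 in one place: a group of 10 heavy atoms (6 carbon, 3 nitrogen, 1 oxygen; one five-membered aromatic ring with 1 hetero atom, one six-membered aromatic ring with 2 hetero atoms) in place of a group of 12 heavy atoms (6 carbon, 3 nitrogen, 2 fluorine, 1 chlorine; one five-membered aromatic ring with 2 hetero atoms, one six-membered aromatic ring with 1 hetero atom), on a saturated chain carbon bound to a double-bonded chain carbon. Two five-atom-plus-ring systems swap, with the fluorine and chlorine atoms leaving and a hydrogen-bond donor and an oxygen entering.

Nothing in the measured set speaks to this swap, so no step beyond the scatter is expected in this assay, in either direction. Compound 4 is therefore estimated at 55000 nM, with a range from 15000 nM to 150000 nM, which would mean a step of a 1.4-fold lower number from compound 2 to compound 4 (0.15 log units; within the scatter).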

Compound 4, half-maximal inhibitory concentration: > 100000 nM
Compound 4: only a limit was reported (the forecaster's own chance of this, stated with the estimate: 25%); middle value at least 1.8-fold (0.25 log units) away from the limit.
By their numbers in this assay, from the lowest: compound 1; then compounds 3 and 2 (each within the scatter of the next). At a limit, above all of these: compound 4.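

In this assay compound 4 is reported only as a limit, > 100000 nM. Putting the group of 10 heavy atoms, with its hydrogen-bond donor, in place of the group of 12 heavy atoms that carries fluorine and chlorine, on a saturated chain carbon bound to a double-bonded chain carbon, gives an at least 1.2-fold higher number from compound 2 to compound 4 (0.10 log units; that floor lies within the scatter), so this change brings no gain in growth inhibition at this position. Only a floor for the step can be read, not its true size: the limit of > 100000 nM in this assay, at which 1 of the 4 values shown sits.

The swap changes the rings and removes the halogen atoms in one move, so the compounds shown do not separate the two effects. They also leave open how a single smaller change on the group of 12 heavy atoms would read, such as an amine or a methoxy group in place of one fluorine.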